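Cytotoxicity of a thiocarbamate pair and a naphthyl analogue

The compounds below may be only part of what the source reports. "The series", "measured", "known", "first", "only" and "open" are said of these compounds alone.

Measured compounds:
compound 1, `O=C1c2ccccc2C(=O)N1CCOC(=S)N(C(=O)c1ccc(C(F)(F)F)cc1)c1ccc(Cl)cc1`, 10000 nM
compound 2, `COc1cccc(OC)c1C(=O)N(C(=S)OCCN1C(=O)c2ccccc2C1=O)c1ccc(C)cc1`, 36000 nM

Both compounds were tested in an ADME assay on MT4 cells (Homo sapiens) for cytotoxicity, read by MTT assay; on this read-out higher numbers stand for lower toxicity in this test and lower numbers for higher toxicity in this test. Of the two, compound 1 gives the lower number, 10000 nM, while compound 2 gives 36000 nM; the gap between them lies beyond the usual scatter, so compound 1 is the more toxic of the pair in this assay.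

Compound 3, `O=C1c2ccccc2C(=O)N1CCOC(=S)N(C(=O)c1cccc2ccccc12)c1ccc(Cl)cc1`, has not yet been measured. It differs from compound 1 in one place: naphthalen-1-yl in place of 4-(trifluoromethyl)phenyl on a carbonyl carbon. Among the compounds with values here, no measured pair shows what this particular change does, so the direction is uncertain. Since compound 1 gives 10000 nM and nothing shown argues for a move in either direction, compound 3 is expected to land close to that value, with a step of no change at the digits printed from compound 1 to compound 3 (within the scatter) that is no larger than the scatter. The estimate for compound 3 is therefore 10000 nM, in a range from 3000 nM to 35000 nM.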

Compound 3, half-maximal cytotoxic concentration: 6000 nM
For compound 3 the middle estimate is 1.7-fold (0.22 log units) above the measured one, and the stated range covers the measured number.
By their numbers in this assay, from the lowest: compounds 3 and 1 (each within the scatter of the next); then compound 2.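

At the carbonyl carbon bonded to the amide-type nitrogen, this assay shows naphthalen-1-yl in place of 4-(trifluoromethyl)phenyl as a 1.7-fold lower number from compound 1 to compound 3 (0.22 log units; within the scatter), so this test does not tell the two compounds apart. The swap keeps the count of 10 heavy atoms, yet it replaces a ring bearing three fluorine atoms with an all-carbon group of two aromatic rings, so this position can undergo a sizeable change in make-up with no readable shift in the number. No separate measurement here speaks to why the two compounds read alike.

Still open, as far as these compounds go, is how the number behaves when this position carries a group of another kind, such as an amine, a carboxylic acid or a longer chain. From the compounds shown here alone, it is also open whether the same swap would read alike on a different core.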